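A few compounds are considered here, and "the series" means these few. Any claim that something is new, unique, unknown or untested is made for them only; others in the source may bear on it.

Compound 3 `N#Cc1c(-c2ccc(Cl)cc2)cc(-c2ccc(Cl)cc2)n([C@@H]2O[C@H](CO)[C@@H](O)[C@H](O)[C@H]2O)c1=O` carries 3,4,5-trihydroxy-6-(hydroxymethyl)oxan-2-yl on an aromatic nitrogen of the shared core; in a functional assay on MCF7 cells (Homo sapiens) for cytotoxicity, read by sulforhodamine B assay, with a stated time of 48 h (a higher number here means a weaker inhibitor, a lower number a stronger inhibitor), compound 3 gives 14.2 ug/mL. Among the three numbers measured it stands second highest: compound 1 `C#CCn1c(-c2ccc(Cl)cc2)cc(-c2ccc(Cl)cc2)c(C#N)c1=O` gives 16.7 ug/mL, and compound 2 `N#Cc1c(-c2ccc(Cl)cc2)cc(-c2ccc(Cl)cc2)n([C@@H]2O[C@H](CO)[C@@H](O)[C@H]2O)c1=O` gives 5.7 ug/mL. The step of a 1.2-fold lower number from compound 1 to compound 3 (0.07 log units; within the scatter) lies within the scatter, whereas a 2.5-fold higher number from compound 2 to compound 3 (0.40 log units; beyond the scatter) is a modest step. Compound 4 `CCn1c(-c2ccc(Cl)cc2)cc(-c2ccc(Cl)cc2)c(C#N)c1=O` has not yet been measured; it differs from compound 3 by ethyl in place of 3,4,5-trihydroxy-6-(hydroxymethyl)oxan-2-yl on an aromatic nitrogen. Going by the values given here, the only measured step that bears on a short chain in place of this group, a 1.2-fold lower number from compound 1 to compound 3 (0.07 log units; within the scatter), stayed within the scatter, so no step beyond the scatter is expected in this assay. Compound 4 is therefore estimated at 15 ug/mL, in a range from 7 ug/mL to 35 ug/mL, an expected step of a 1.1-fold higher number from compound 3 to compound 4 (0.02 log units; within the scatter).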

Compound 4, half-maximal inhibitory concentration: 19.7 ug/mL
Compound 4: middle estimate off by 1.3-fold (0.12 log units), on the low side; the measured number falls inside the stated range.
By their numbers in this assay, from the lowest: compound 2; then compounds 3, 1 and 4 (each within the scatter of the next).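

In this assay, ethyl on the aromatic nitrogen cannot be told apart from propargyl, a 1.2-fold higher number from compound 1 to compound 4 (0.07 log units; within the scatter), or from 3,4,5-trihydroxy-6-(hydroxymethyl)oxan-2-yl, a 1.4-fold higher number from compound 3 to compound 4 (0.14 log units; within the scatter), so neither the small chain's identity nor this much larger group moves the number measurably. Against ethyl too, 3,4-dihydroxy-5-(hydroxymethyl)oxolan-2-yl stands apart, a 3.5-fold higher number from compound 2 to compound 4 (0.54 log units; beyond the scatter), leaving compound 2 alone beyond the scatter of all three others. No measurement shown here accounts for that difference. The compounds shown leave open whether an amine, a carboxylic acid or a longer chain on this nitrogen would match compound 2 or stay with the other three.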